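The compounds below may be only part of what the source reports. "The series", "measured", "known", "first", "only" and "open" are said of these compounds alone.

Working notes on the series. Compound 1 `COc1cccc2cc(C(=O)NCC(=O)O)c(=O)oc12` and compound 2 `O=C(NCCCO)c1cc2ccccc2oc1=O` carry the same amide-bearing core. In an assay on CHO cells for displacement of a labelled ligand from adenosine receptor A1 (Homo sapiens), read by scintillation counting, with a stated time of 60 min, tested at 10 uM (a lower number here means less inhibition, a higher number more inhibition at the concentration tested (going by the name of the read-out)), compound 1 gives 27%, and in this assay compound 2 gives 24%; these two numbers fall within the usual scatter of each other, so compound 2 is not set apart from compound 1. Compound 3 `O=C(O)CNC(=O)c1cc2ccccc2oc1=O` differs from compound 2 by carboxy in place of 2-hydroxyethyl on a saturated chain carbon bound to an amide-type nitrogen. Among the compounds with values here, no measured step covers this change. The step from compound 2 to compound 3 is expected to be a number 1 percentage points higher from compound 2 to compound 3 (within the scatter), that is, nothing beyond the scatter. Compound 1 carries the same carboxymethyl chain and gives 27%. On that basis compound 3 is expected to give 25%, in the range 10% to 40%.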

Compound 3, a percentage reported as inhibition, at one concentration (the size of the read-out at that concentration, not a potency): 1%
Compound 3: the middle estimate sits 24 percentage points above what was measured; the whole stated range lies above it.
By their numbers in this assay, from the lowest: compound 3; then compounds 2 and 1 (each within the scatter of the next).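

In this assay, carboxy in place of 2-hydroxyethyl on a saturated chain carbon bound to an amide-type nitrogen gives a number 23 percentage points lower from compound 2 to compound 3 (beyond the scatter). With the carboxymethyl chain kept, hydrogen in place of methoxy on an aromatic carbon gives a number 26 percentage points lower from compound 1 to compound 3 (beyond the scatter). The closeness of compound 1 and compound 2 therefore does not mean that either place is without weight, and nothing at hand explains either step.

Open, from the compounds shown here alone, is whether the methoxy step holds with the 3-hydroxypropyl chain. Also open, going by these compounds, is how an amine or a methyl ester would read in place of carboxy.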